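Working notes on the shared core: compound 2 to compound 4

The source may hold more compounds than are shown below. What is called first, only, known or untested is meant among the compounds shown, and "the series" means these compounds.

Of the compounds shown here, three of the shared core have so far been tested in a functional assay on SW480 cells (Homo sapiens) for cytotoxicity, read by MTT assay, with a stated time of 24 h; on this read-out higher numbers stand for weaker inhibition and lower numbers for stronger inhibition. Compound 1 `C=CC1=C(C(=O)NCc2ccc(C)cc2)C(c2ccc(F)cc2)OC1` gives > 100000 nM, which is a limit of the assay and not a measured number. Compound 2 `C=CC1=C(C(=O)NC(C)(C)C)C(c2ccc(OC)cc2)OC1` gives > 100000 nM, again a limit rather than a figure. Compound 3 `C=CC1=C(C(=O)NCc2ccccc2)C(c2ccc(Cl)c(Cl)c2)OC1` gives > 100000 nM, also a limit. Compound 2 therefore stands at the same limit as the other two tested compounds, and no ordering among the three can be read from the numbers, as summarised by the limit of > 100000 nM in this assay, at which 3 of the 3 values shown sit. Compound 4 `C=CC1=C(C(=O)Nc2ccc(C)cc2)C(c2ccc(OC)cc2)OC1` has not yet been measured. It differs from compound 2 in one place: 4-methylphenyl in place of tert-butyl on an amide-type nitrogen. Among the compounds with values here, no step between two measured compounds is available, and the three recorded limits give no indication of what the group on the amide-type nitrogen contributes to the read-out. The expectation is that the step of a number no higher from compound 2 to compound 4 (the limit leaves the size open) amounts to none beyond the usual scatter. Compound 4 is accordingly expected to give 100000 nM, within a range from 30000 nM to 300000 nM, most probably reported as a further limit rather than a number.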

Compound 4, half-maximal inhibitory concentration: > 100000 nM
Compound 4: a limit, no number; the forecaster's own chance of this, stated with the estimate: 80%; the middle value sits exactly at the limit.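

In this assay compound 4 gives > 100000 nM, a limit and not a number. Compound 2 also stands at a limit, so no step can be read between compound 2 and compound 4. What the group on the amide-type nitrogen contributes to the read-out stays open, with every compound shown sitting at one limit: the limit of > 100000 nM in this assay, at which 4 of the 4 values shown sit.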